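Working notes: cytotoxicity of compounds 1 to 4

A few compounds are considered here, and "the series" means these few. Any claim that something is new, unique, unknown or untested is made for them only; others in the source may bear on it.

Measured in an ADME assay on J774.1 cells (Mus musculus) for cytotoxicity, read by MTT assay, with a stated time of 48 h; on this read-out lower numbers stand for stronger inhibition and higher numbers for weaker inhibition:
compound 1 `Cc1c(/C=N/NC(=O)c2cccnc2)no[n+]1[O-]` — compound 1 gives > 400000 nM, which is a limit of the assay and not a number.
compound 2 `O=C(N/N=C/c1ccc2no[n+]([O-])c2c1)c1cccnc1` — compound 2 gives 31000 nM.
compound 3 `Cc1[nH]cnc1C(=O)N/N=C/c1ccc2no[n+]([O-])c2c1` — compound 3 gives 33900 nM.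

From compound 2 to compound 3 the change is 5-methyl-1H-imidazol-4-yl in place of pyridin-3-yl on a carbonyl carbon, and it gave a 1.1-fold higher number from compound 2 to compound 3 (0.04 log units; within the scatter). Compound 1 and compound 2 carry different cores; the difference between the two cores is not broken down here. Compound 4 `Cc1[nH]cnc1C(=O)N/N=C/c1no[n+]([O-])c1C` is not yet measured in this assay. It differs from compound 1 by 5-methyl-1H-imidazol-4-yl in place of pyridin-3-yl on a carbonyl carbon, the same change as from compound 2 to compound 3, at the same place. For compound 1 only the limit of > 400000 nM in this assay, at which 1 of the 3 values shown sits, is known. The step to compound 4 is expected to be a step that the limit leaves unreadable from compound 1 to compound 4 because a 1.1-fold higher number from compound 2 to compound 3 (0.04 log units; within the scatter) stayed within the scatter. Compound 4 is therefore expected to give 450000 nM, between 200000 nM and 1000000 nM, most likely reported again as a limit.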

Compound 4, half-maximal inhibitory concentration: > 400000 nM
Compound 4 ended at the assay's limit (the forecaster's own chance of this, stated with the estimate: 80%); the middle value does not contradict the limit.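

No step can be read from compound 1 to compound 4, because both compounds stand at the same limit of the assay: the limit of > 400000 nM in this assay, at which 2 of the 4 values shown sit.

As far as these compounds go, what 5-methyl-1H-imidazol-4-yl in place of pyridin-3-yl does on the core of compound 1 stays open.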